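A few compounds are considered here, and "the series" means these few. Any claim that something is new, unique, unknown or untested is made for them only; others in the source may bear on it.

Measured compounds:
- `Cc1ccc(C)n1-c1ccc(C(=O)N/N=C/c2ccc(N(C)C)cc2)cc1`, compound 1: in an ADME assay on A549 cells (Homo sapiens) for cytotoxicity, read by MTT assay, with a stated time of 72 h (on this read-out lower numbers stand for stronger inhibition and higher numbers for weaker inhibition), compound 1 gives "not determined" (no result reported).
- `CC(=O)N1N=C(c2ccc(-n3c(C)ccc3C)cc2)OC1c1ccc(Br)cc1`, compound 2: 195000 nM.
- `Cc1ccc(C)n1NC(=O)c1ccc(-n2c(C)ccc2C)cc1`, compound 3: 225000 nM.

Compound 2 carries the lower of the two reported numbers, but its value and that of compound 3 lie within the scatter of each other, so the two cannot be told apart on this read-out.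

Compound 4, `CC(=O)N1N=C(c2ccc(-n3c(C)ccc3C)cc2)OC1c1c(Cl)cccc1Cl`, differs from compound 2 only here: 2,6-dichlorophenyl in place of 4-bromophenyl on a saturated ring carbon. For the measured compounds named here, no measured pair shows what such a change does on this read-out, so the expectation rests on compound 2 alone. The step is expected to be small, in either direction and not beyond the scatter, giving a 1.1-fold lower number from compound 2 to compound 4 (0.03 log units; within the scatter). Compound 4 is therefore estimated at 180000 nM, within 60000 nM to 450000 nM.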

Compound 4, half-maximal inhibitory concentration: 224000 nM
Estimate against measurement, compound 4: 1.2-fold (0.09 log units) below; low and high end bracket the measured number.
By their numbers in this assay, from the lowest: compounds 2, 4 and 3 (each within the scatter of the next).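

In this assay the exchange of 4-bromophenyl for 2,6-dichlorophenyl on the saturated ring carbon gives a 1.1-fold higher number from compound 2 to compound 4 (0.06 log units; within the scatter) and thus a direct reading at this position: one halogen-bearing phenyl group can replace another here with no change beyond the scatter. Nothing measured here explains why the two groups read alike.

From the compounds shown here alone, both groups are halogen-bearing phenyl rings, so the effect of something quite different on this carbon, such as an amine or a carboxylic acid, stays open. Going by these compounds, the part played by the acetyl group also stays open.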